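Aryl group swap on the amide-type nitrogen: compound 3

The compounds below may be only part of what the source reports. "The series", "measured", "known", "first", "only" and "open" are said of these compounds alone.

In a functional assay on RT-112 cells (Homo sapiens) for antiproliferative activity, read by MTT assay, with a stated time of 72 h (on this read-out higher numbers stand for weaker inhibition of growth and lower numbers for stronger inhibition of growth), compound 1 (`COc1cc(Nc2ncnc3c(NC(=O)Nc4cccc(Cl)c4Cl)cccc23)cc(OC)c1`) gives 63.2 nM, and compound 2 (`COc1cc(Nc2ncnc3c(NC(=O)Nc4cccc(C(F)(F)F)c4F)cccc23)cc(OC)c1`) gives 471 nM. Compound 2 therefore holds the higher number of the pair, which means the weaker inhibition of growth. Compound 3 (`CCOC(=O)c1ccc(NC(=O)Nc2cccc3c(Nc4cc(OC)cc(OC)c4)ncnc23)cc1`) keeps the rest of compound 2 and changes one group: 4-(ethoxycarbonyl)phenyl in place of 2-fluoro-3-(trifluoromethyl)phenyl on an amide-type nitrogen. Unlike the group that leaves, 4-(ethoxycarbonyl)phenyl brings hydrogen-bond acceptors and a double bond outside aromatic rings.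

For the measured compounds named here, only one measured step bears on this change: a 7.5-fold higher number from compound 1 to compound 2 (0.87 log units; beyond the scatter). It exchanges groups at the same amide-type nitrogen and shows that the number in this assay can move with such an exchange. Going by the values given here, that single step gives no direction for 4-(ethoxycarbonyl)phenyl, since no measured compound carries this group. The central expectation in this assay is therefore no step beyond the scatter, with wide margins on either side. The estimated step is a 1.6-fold lower number from compound 2 to compound 3 (0.20 log units; within the scatter). For compound 3 the expected value is 300 nM, with an estimated range of 70 nM to 1300 nM.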

Compound 3, concentration for 50% growth inhibition: 317 nM
The estimate for compound 3 lay 1.1-fold (0.02 log units) below the measured number; the measured number falls inside the stated range.
By their numbers in this assay, from the lowest: compound 1; then compounds 3 and 2 (each within the scatter of the next).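

At the amide-type nitrogen, 4-(ethoxycarbonyl)phenyl and 2-fluoro-3-(trifluoromethyl)phenyl cannot be told apart in this assay, with a 1.5-fold lower number from compound 2 to compound 3 (0.17 log units; within the scatter) even though the entering group brings hydrogen-bond acceptors and a double bond outside aromatic rings that the leaving group lacks. Against 2,3-dichlorophenyl the same exchange gives a 5.0-fold higher number from compound 1 to compound 3 (0.70 log units; beyond the scatter) and compound 1 thus stands as the strongest inhibitor of growth of the three, with two quite different aryl groups both on the far side of the scatter from it. No measurement at hand accounts for either step.

Still open, going by these compounds, is whether the ethoxycarbonyl group itself contributes anything at this nitrogen, a question that a carboxylic acid or a primary amide in its place would address. Also open, on these data alone, is how much of the lower number of compound 1 depends on having both chlorines, which an unsubstituted phenyl or a phenyl carrying a single chlorine on the same nitrogen would help to separate.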